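Swapping One Aromatic Group on a Shared Core

The source may report more compounds than this note shows. Statements on the series, on what has been measured and on what is new or still open speak of the compounds shown alone.

- Compound 1 `C=C/C=C\[C@H](C)[C@H](OC(N)=O)[C@@H](C)[C@H](O)[C@@H](C)C/C(C)=C\[C@H](C)[C@@H](O)[C@@H](C)/C=C\CCc1ccc(C)c(O)c1` gives 770 nM here
- Compound 2 `C=C/C=C\[C@H](C)[C@H](OC(N)=O)[C@@H](C)[C@H](O)[C@@H](C)C/C(C)=C\[C@H](C)[C@@H](O)[C@@H](C)/C=C\CCc1ccsc1` gives 850 nM here

For the measured compounds named here, compound 2 gives 850 nM in a functional assay on MCF7 cells (Homo sapiens) for cytotoxicity (a lower number here means a stronger inhibitor, a higher number a weaker inhibitor), and cannot be told apart from compound 1, the only other measured compound. The step between them is a 1.1-fold higher number from compound 1 to compound 2 (0.04 log units; within the scatter) and it shows no real difference.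

Compound 3 `C=C/C=C\[C@H](C)[C@H](OC(N)=O)[C@@H](C)[C@H](O)[C@@H](C)C/C(C)=C\[C@H](C)[C@@H](O)[C@@H](C)/C=C\CCc1cc(O)cc(O)c1` keeps the shared core and differs from compound 2 in one group, with 3,5-dihydroxyphenyl in place of thiophen-3-yl on a saturated chain carbon (3,5-dihydroxyphenyl in place of thiophen-3-yl on a saturated chain carbon, two bonds along the chain from a double-bonded chain carbon).

Going by the values given here, one measured step bears on this change. At the same place, 3-hydroxy-4-methylphenyl gave way to thiophen-3-yl in the step of a 1.1-fold higher number from compound 1 to compound 2 (0.04 log units; within the scatter) and the number stayed within the scatter. Among the compounds with values here, that is thin evidence, since no compound carrying 3,5-dihydroxyphenyl has been measured, so a larger shift in either direction cannot be ruled out. No step beyond the scatter is expected, and the expected step is a 1.1-fold lower number from compound 2 to compound 3 (0.03 log units; within the scatter) in this assay with no clear direction. Compound 3 is estimated at 800 nM with 300 nM to 2200 nM as the expected range.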

Compound 3, half-maximal inhibitory concentration: 160 nM
For compound 3 the middle estimate is 5.0-fold (0.70 log units) above the measured one; the whole stated range lies above it.
By their numbers in this assay, from the lowest: compound 3; then compounds 1 and 2 (each within the scatter of the next).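

This position does respond to the aromatic group it carries: in this assay, 3,5-dihydroxyphenyl in place of thiophen-3-yl gives a 5.3-fold lower number from compound 2 to compound 3 (0.73 log units; beyond the scatter), and in place of 3-hydroxy-4-methylphenyl it gives a 4.8-fold lower number from compound 1 to compound 3 (0.68 log units; beyond the scatter). Both steps lie beyond the scatter, so compound 3 stands apart from the other two, even though the earlier swap of aromatic groups at this place produced no real difference. The ring of compound 1 also carries a hydroxy group, so among these compounds a hydroxy group on the ring is not enough on its own to give the lower number, and no measurement shown here explains what sets 3,5-dihydroxyphenyl apart.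

The compounds shown leave open whether the free hydroxy groups themselves matter, which a 3,5-dimethoxyphenyl group at this place would test, and whether both are needed, which a plain 3-hydroxyphenyl group would test. They also leave open whether a longer chain carrying the 3,5-dihydroxyphenyl group would keep the lower number.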